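Swapping the amine on the shared core: butylamino to dimethylamino

A few compounds are considered here, and "the series" means these few. Any claim that something is new, unique, unknown or untested is made for them only; others in the source may bear on it.

Measured so far:
compound 1, `Cc1c(N(C)C)c(=O)n(C)c(=O)n1C`, 0.99
compound 2, `CCCCNc1c(C)n(C)c(=O)n(-c2ccccc2)c1=O`, 1.69

Of the compounds shown here, two have been measured in a physicochemical assay for lipophilicity; a lower number here means a more polar compound, a higher number a more lipophilic compound. Compound 1 has the structure `Cc1c(N(C)C)c(=O)n(C)c(=O)n1C` and gives 0.99. Compound 2, `CCCCNc1c(C)n(C)c(=O)n(-c2ccccc2)c1=O`, gives 1.69 in this assay. Of the two numbers, compound 2 stands highest; its nearest neighbour is compound 1, which lies lower by a margin beyond the usual scatter of such measurements.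

The next compound, compound 3, has the structure `Cc1c(N(C)C)c(=O)n(-c2ccccc2)c(=O)n1C` and has not yet been measured in this assay. It differs from compound 2 in one place: dimethylamino in place of butylamino on an aromatic carbon.

Among the measured compounds shown here, no measured pair shows the effect of this particular change, so the expectation rests on the change itself and on the value of compound 2. The step of a number 0.21 log units higher from compound 2 to compound 3 (within the scatter) is estimated to be small, and it is expected to remain within the scatter of this assay rather than to move clearly in either direction. For compound 3 in this assay the estimate is 1.9, with a plausible range from 1.2 to 2.6.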

Compound 3, partition coefficient: 1.3
Estimate against measurement, compound 3: 0.60 log units above; low and high end bracket the measured number.
By their numbers in this assay, from the lowest: compound 1; then compound 3; then compound 2.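

Compound 3 separates two changes that were tangled together in the earlier pair, since compound 1 and compound 2 differ in more than one place. In this assay, dimethylamino in place of butylamino on this aromatic carbon gives a number 0.39 log units lower from compound 2 to compound 3 (beyond the scatter), the first measured size for this amine swap, while phenyl in place of methyl on an aromatic nitrogen gives a number 0.31 log units higher from compound 1 to compound 3 (beyond the scatter), so each change now has its own modest step beyond the scatter. Nothing measured here explains why either step has the size it does.

Going by these compounds, each change is still seen only once, so it remains open whether the amine swap would give a step of the same size on the core of compound 1, which carries methyl rather than phenyl on the aromatic nitrogen. The compounds shown also leave open where a plain amino group, a morpholine or a longer chain such as hexylamino would fall in this assay when placed on this same aromatic carbon.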